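Replacing the carboxymethyl group of compound 3 with methylcarbamoyl

The compounds below may be only part of what the source reports. "The series", "measured", "known", "first", "only" and "open" are said of these compounds alone.

Of the compounds shown here, three sharing one core have been tested in a functional assay on the whole organism for inhibition, with Rattus norvegicus as the target; a higher number here means that more compound is needed for the effect, a lower number that less compound is needed. Compound 1 `CC1CC/C(=N\Nc2ccc(Cl)cc2)c2ncc(C(=O)O)c(=O)n21` gives 0.5 umol/kg. Compound 2 `CC1CC/C(=N\Nc2ccc(O)cc2)c2ncc(C(=O)O)c(=O)n21` gives 1.7 umol/kg, and compound 3 `CC1CC/C(=N\Nc2ccc(CC(=O)O)cc2)c2ncc(C(=O)O)c(=O)n21` gives 60.9 umol/kg. Compound 3 therefore stands at the highest number of the three, with the smallest gap to compound 2 and the widest to compound 1.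

Compound 4 `CNC(=O)c1ccc(N/N=C2\CCC(C)n3c2ncc(C(=O)O)c3=O)cc1` differs from compound 3 in one place: methylcarbamoyl in place of carboxymethyl on an aromatic carbon The group sits on an aromatic carbon of a six-membered aromatic ring of carbon only, para to a large group.

Within the data shown here, no measured step covers methylcarbamoyl itself. Among the measured compounds shown here, the steps that bear on the position are a 120-fold higher number from compound 1 to compound 3 (2.09 log units; beyond the scatter) and a 36-fold higher number from compound 2 to compound 3 (1.55 log units; beyond the scatter), both large, showing that the carboxymethyl group carries the highest number of the set. Removing it is expected to bring the number down in this assay, though with no reference for the entering group the size is uncertain; a moderate fall, a 7.6-fold lower number from compound 3 to compound 4 (0.88 log units; beyond the scatter), is estimated. Compound 4 is expected to give about 8 umol/kg, within a range from 1.5 umol/kg to 40 umol/kg.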

Compound 4, dose for 50% inhibition: 9.6 umol/kg
For compound 4 the middle estimate is 1.2-fold (0.08 log units) below the measured one; low and high end bracket the measured number.
By their numbers in this assay, from the lowest: compound 1; then compound 2; then compound 4; then compound 3.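

In this assay, a change between two groups with the same count of heavy atoms still gives a 6.3-fold lower number from compound 3 to compound 4 (0.80 log units; beyond the scatter), so the high number of compound 3 does not follow from that count alone. Methylcarbamoyl does not reach the two smaller groups, however: the steps are a 5.6-fold higher number from compound 2 to compound 4 (0.75 log units; beyond the scatter) and a 19-fold higher number from compound 1 to compound 4 (1.28 log units; beyond the scatter), which leaves chloro with the lowest number of the four compounds. Nothing measured here accounts for these differences.

The compounds shown leave open how a carboxylic acid placed directly on the same aromatic carbon, an amine or a longer chain would compare. They also leave open whether the amide hydrogen matters, a question that dimethylcarbamoyl, which lacks it, would address.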